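The compounds below may be only part of what the source reports. "The series", "measured", "known", "first", "only" and "open" are said of these compounds alone.

Compound 3 `CC(O)CCn1nc2c(Br)c(Br)c(Br)c(Br)c2n1` stands highest of the three numbers in a functional assay on MCF7 cells (Homo sapiens) for antiproliferative activity, read by MTT assay, with a stated time of 48 h, tested at 50 uM (on this read-out higher numbers stand for a weaker effect at the one concentration tested and lower numbers for a stronger effect), where compound 3 gives 76%. Compound 1 `OC(CCn1nc2c(Br)c(Br)c(Br)c(Br)c2n1)c1cccc(Br)c1` gives 11% and compound 2 `OC(CCn1nc2c(Br)c(Br)c(Br)c(Br)c2n1)c1cccc(Cl)c1` gives 12% in this assay, and the step of a number 1 percentage points higher from compound 1 to compound 2 (within the scatter) lies within the scatter. Compound 4 `OC(CCn1nc2c(Br)c(Br)c(Br)c(Br)c2n1)c1ccc(Cl)cc1` differs from compound 3 by 4-chlorophenyl in place of methyl on a saturated chain carbon bound to an oxygen on a saturated carbon and a saturated chain carbon. Going by the values given here, the steps that bear on this change run the other way, from an aryl group to methyl: a number 65 percentage points higher from compound 1 to compound 3 (beyond the scatter) and a number 64 percentage points higher from compound 2 to compound 3 (beyond the scatter), both large. For compound 4 a large drop in this assay is therefore expected, a number 61 percentage points lower from compound 3 to compound 4 (beyond the scatter), because 4-chlorophenyl enters where compound 1 with 3-bromophenyl gave 11% and compound 2 with 3-chlorophenyl gave 12%. Compound 4 is estimated at 15%, with a range from 5% to 35%.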

Compound 4, a percentage reported as activity, at one concentration (the size of the read-out at that concentration, not a potency): 9%
For compound 4 the middle estimate is 6 percentage points above the measured one; the range from low to high includes it.
By their numbers in this assay, from the lowest: compounds 4, 1 and 2 (each within the scatter of the next); then compound 3.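

In this assay, 4-chlorophenyl in place of methyl on this saturated chain carbon gives a number 67 percentage points lower from compound 3 to compound 4 (beyond the scatter), so the large step seen with 3-bromophenyl and 3-chlorophenyl holds for a third aryl group. The aryl groups themselves cannot be told apart here: a number 3 percentage points lower from compound 2 to compound 4 (within the scatter) and a number 2 percentage points lower from compound 1 to compound 4 (within the scatter) both stay small.

Going by these compounds, whether unsubstituted phenyl, a pyridine ring or a longer chain in this place would give a number like those of the aryl compounds stays open. No measured evidence is available to explain the size of the step from methyl to an aryl group.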